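The source may hold more compounds than are shown below. What is called first, only, known or untested is meant among the compounds shown, and "the series" means these compounds.

Compounds measured in an assay on CHO cells for agonist activity at 5-hydroxytryptamine receptor 1D (Homo sapiens), read by GTPgammaS binding; a higher number here means that more compound is needed for the effect, a lower number that less compound is needed:
compound 1, `CN(Cc1cccs1)C1CCN(CCCc2c[nH]c3ccc(-n4cnnc4)cc23)CC1`, 3.5 nM;
compound 2, `c1ccc(CNC2CCN(CCCc3c[nH]c4ccc(-n5cnnc5)cc34)CC2)cc1`, 7.6 nM.

Compound 2 shows the highest number of the two, with compound 1 nearest at a 2.2-fold higher number from compound 1 to compound 2 (0.34 log units; beyond the scatter) the other way. Compound 3, `CC(C)=CCN(C)C1CCN(CCCc2c[nH]c3ccc(-n4cnnc4)cc23)CC1`, carries methyl(3-methylbut-2-en-1-yl)amino in place of benzylamino on a saturated ring carbon. Going by the values given here, only that one step bears on this change: compound 1 also bears a methyl on the amine, and compound 1 to compound 2 gave a 2.2-fold higher number from compound 1 to compound 2 (0.34 log units; beyond the scatter). Compound 3 keeps the methyl but trades the aromatic ring for an open chain, so a modest lowering is expected, a 1.5-fold lower number from compound 2 to compound 3 (0.18 log units; within the scatter). Compound 3 is estimated at 5 nM, between 1.5 nM and 16 nM.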

Compound 3, half-maximal effective concentration: 1.8 nM
Compound 3: middle estimate off by 2.8-fold (0.44 log units), on the high side, and the stated range covers the measured number.
By their numbers in this assay, from the lowest: compounds 3 and 1 (each within the scatter of the next); then compound 2.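

In this assay, the change at this saturated ring carbon gave a 4.2-fold lower number from compound 2 to compound 3 (0.63 log units; beyond the scatter), so an aromatic ring is not required here: methyl(3-methylbut-2-en-1-yl)amino, with no ring, serves at least as well as benzylamino. On the methyl-bearing amine, the swap of thiophen-2-yl for 2-methylprop-1-en-1-yl gave a 1.9-fold lower number from compound 1 to compound 3 (0.29 log units; within the scatter), so these two ends cannot be told apart. Nothing available explains either step. The change from compound 2 to compound 3 alters the amine methyl and the aromatic ring together, leaving their separate shares open. As far as these compounds go, whether a saturated 3-methylbutyl chain would match the 3-methylbut-2-en-1-yl chain also remains open.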